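A few compounds are considered here, and "the series" means these few. Any claim that something is new, unique, unknown or untested is made for them only; others in the source may bear on it.

Of the compounds shown here, three that share one core have been tested in an assay on cells for displacement of a labelled ligand from adenosine receptor A1 (Homo sapiens), read by scintillation counting, with a stated time of 3 h; a higher number here means a weaker inhibitor, a lower number a stronger inhibitor. Compound 1 `COc1ccc(-c2cn3c(=O)n(-c4ccccc4)nc3c(=O)[nH]2)cc1` carries a methyl on an oxygen on an aromatic ring. For compound 1 the result is a limit of the assay rather than a number, > 30000 nM. Compound 2 `O=c1[nH]c(-c2ccc(O)cc2)cn2c(=O)n(-c3ccccc3)nc12` has a hydrogen on that oxygen instead, and compound 2 gives 616 nM. Among the compounds with values here, that single change, an at least 48-fold lower number from compound 1 to compound 2 (1.68 log units; beyond the scatter), is the only step between measured compounds that differ in one place. Compound 3 `Nc1nc(-c2ccc(O)cc2)cn2c(=O)n(-c3ccccc3)nc12` carries an amine where compound 2 carries a carbonyl, and compound 3 gives 45 nM, the lowest of the numbers shown, with compound 2 as its nearest neighbour at a clearly higher number.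

Compound 4 `CC(C)Oc1ccc(-c2cn3c(=O)n(-c4ccccc4)nc3c(N)n2)cc1` has not yet been measured. It differs from compound 3 by isopropyl in place of hydrogen on an oxygen on an aromatic ring. Within the data shown here, this is the reverse of the only measured step, with a larger alkyl group in place of the methyl, and that step was large. Because the methyl cap on the same oxygen gave an at least 48-fold lower number from compound 1 to compound 2 (1.68 log units; beyond the scatter), an isopropyl cap is expected to raise the number by a 56-fold higher number from compound 3 to compound 4 (1.74 log units; beyond the scatter). Compound 4 is therefore expected near 2500 nM, most likely between 300 nM and 25000 nM.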

Compound 4, inhibition constant: > 30000 nM
Compound 4 gave a limit, no number; the forecaster's own chance of this, stated with the estimate: 20%; middle value at least 12-fold (1.07 log units) from the limit.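

Replacing hydroxy with isopropoxy in this assay gives an at least 660-fold higher number from compound 3 to compound 4 (2.82 log units; beyond the scatter), so the free hydroxy group matters on the amine-bearing core as well as on the carbonyl-bearing core of compound 1 and compound 2. Capping this oxygen goes with a large rise in the number in both pairs, methyl in one and isopropyl in the other, and even the low starting value of compound 3 does not protect against it. The true size of the new step cannot be read, because the value of compound 4 is a limit and not a number: the limit of > 30000 nM in this assay, at which 2 of the 4 values shown sit.

From the compounds shown here alone, it remains open how a smaller cap such as an ethyl group on this oxygen would read on the amine-bearing core, and so whether the loss comes with any cap or only with some. Going by these compounds, it is also open whether another group able to replace the hydroxy group on the aromatic ring, such as an amine or a carboxylic acid, would keep the number as low as that of compound 3.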